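The compounds below may be only part of what the source reports. "The series", "measured", "known", "first", "only" and "open" are said of these compounds alone.

Working notes, values in an ADME assay on C8166 cells (Homo sapiens) for cytotoxicity, read by MTT assay; on this read-out higher numbers stand for lower toxicity in this test and lower numbers for higher toxicity in this test:
- compound 1 `Cc1ccc(C(O)c2cc(Cl)ccc2OCC(=O)Nc2ccc(S(N)(=O)=O)cc2C)cc1` gives 38700 nM
- compound 2 `Cc1cc(S(N)(=O)=O)ccc1NC(=O)COc1ccc(Cl)cc1C(O)c1ccccc1Cl` gives 32000 nM
- compound 3 `Cc1cc(S(N)(=O)=O)ccc1NC(=O)COc1ccc(Cl)cc1C(O)c1ccc(Cl)cc1Cl` gives 39900 nM

The value of compound 3 lies within the scatter of both others, so the three stand level in this assay. Compound 4 `Cc1cc(S(N)(=O)=O)ccc1NC(=O)COc1ccc(Cl)cc1C(O)c1ccc(Cl)c(Cl)c1` differs from compound 3 by 3,4-dichlorophenyl in place of 2,4-dichlorophenyl on a saturated chain carbon bound to an aromatic carbon and an oxygen on a saturated carbon with 3,4-dichlorophenyl in place of 2,4-dichlorophenyl. The closest evidence is a 1.2-fold higher number from compound 2 to compound 3 (0.10 log units; within the scatter) and a 1.0-fold higher number from compound 1 to compound 3 (0.01 log units; within the scatter), with a 1.2-fold lower number from compound 1 to compound 2 (0.08 log units; within the scatter) alongside, all at this same place and all within the scatter. Among the compounds with values here, no measured compound carries the 3,4-dichlorophenyl group, so this remains an extrapolation. The expected change is a 1.1-fold lower number from compound 3 to compound 4 (0.06 log units; within the scatter) and no step beyond the scatter is expected. For compound 4 the estimated value is 35000 nM with an expected range of 16000 nM to 65000 nM.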

Compound 4, half-maximal cytotoxic concentration: 24000 nM
For compound 4 the middle estimate is 1.5-fold (0.16 log units) above the measured one, within the range that was stated.
By their numbers in this assay, from the lowest: compounds 4, 2, 1 and 3 (each within the scatter of the next).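

Up to now, this carbon had carried only 2-chlorophenyl, 4-methylphenyl and 2,4-dichlorophenyl. In this assay, the 3,4-dichlorophenyl group extends the set without leaving the scatter (a 1.7-fold lower number from compound 3 to compound 4 (0.22 log units; within the scatter); a 1.3-fold lower number from compound 2 to compound 4 (0.12 log units; within the scatter); a 1.6-fold lower number from compound 1 to compound 4 (0.21 log units; within the scatter)). Exchanging these two dichlorophenyl groups therefore gives no readable change here, and nothing available bears on a cause.

Still open, as far as these compounds go, is whether a group other than a substituted phenyl on this carbon, such as a pyridine, a carboxylic acid or an amine-bearing chain, would give a step beyond the scatter.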